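This account rests on a few compounds, and the source may have more. Where it says the series, first, only, none or still open, it means among the compounds named here.

Compounds measured so far:
Compound 1 `CS(=O)(=O)Nc1ccc(-c2cc(C(=O)N[C@H]3CCCNC3)c(NC(N)=O)s2)cc1` — "not determined" (no result reported)
Compound 2 `CN(C)c1ccc(-c2cc(C(=O)N[C@H]3CCCNC3)c(NC(N)=O)s2)cc1` — 8400 nM
Compound 3 `NC(=O)Nc1sc(-c2ccc(C(=O)N3CCOCC3)cc2)cc1C(=O)N[C@H]1CCCNC1` — "not determined" (no result reported)

The three compounds share one core and differ only in the group carried on the outer six-membered aromatic ring. In an assay on isolated protein for inhibition of cyclin-dependent kinase 2-associated protein 1 (Homo sapiens) (a higher number here means a weaker inhibitor, a lower number a stronger inhibitor), compound 3 stands without a single number, as its entry carries no result, and compound 1 is in the same position with no result in this assay either. Among the measured compounds shown here, the only figure in hand comes from compound 2, which in this assay gives 8400 nM, a weak inhibition; no step between compound 2 and the other two is given, so their relation is unknown.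

The new member, compound 4 `CS(=O)(=O)c1ccc(-c2cc(C(=O)N[C@H]3CCCNC3)c(NC(N)=O)s2)cc1`, arises from compound 3 by the change (methylsulfonyl in place of (morpholin-4-yl)carbonyl on an aromatic carbon). For the measured compounds named here, no step between measured compounds is recorded anywhere in this set, so the size and direction of this change in this assay cannot be taken from a precedent; it is an open question whether it moves potency beyond the scatter at all. Going by the values given here, the one value available, from compound 2, suggests the series sits in a weak range. Compound 4 is therefore expected to give about 6000 nM, in the range from 1500 nM to 25000 nM, in this assay.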

Compound 4, half-maximal inhibitory concentration: 2200 nM
Compound 4: the middle estimate sits 2.7-fold (0.44 log units) above what was measured; measured number inside the range.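

Compound 4 gives this series its first readable step. In this assay methylsulfonyl in place of dimethylamino on an aromatic carbon, para to a large group, brings a 3.8-fold lower number from compound 2 to compound 4 (0.58 log units; beyond the scatter) and so shows that the group at this place can shift the result beyond the scatter, although compound 4 at 2200 nM remains a weak inhibitor. Steps from compound 1 and compound 3 cannot be read as neither has a number in this assay, so the exchange of (morpholin-4-yl)carbonyl for methylsulfonyl has no measured size, and nothing at hand offers an explanation for the difference between methylsulfonyl and dimethylamino.

On these data alone, it remains open whether other groups at this place, such as a carboxylic acid, a primary amine or a methoxy group, would lower the number further or raise it. Since only this one place varies among the compounds shown, it is also open whether changes elsewhere on the shared core would move the series out of its weak range.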